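The compounds below may be only part of what the source reports. "The series", "measured", "known", "first", "only" and "open" are said of these compounds alone.

The measured compounds:
compound 1, `COc1ccc(OC)c(S(=O)(=O)Nc2cncc(-c3ccncc3)c2)c1`, 73 nM
compound 2, `COc1ccc(Cl)cc1S(=O)(=O)Nc1cncc(C(=O)O)c1`, 134 nM
compound 3, `COc1ccc(C#N)cc1S(=O)(=O)Nc1cccnc1`, 322 nM

All three were tested in an assay on isolated protein for inhibition of alkaline phosphatase, tissue-nonspecific isozyme (Homo sapiens); a lower number here means a stronger inhibitor, a higher number a weaker inhibitor. Among these numbers compound 2 stands close to compound 1: the two values lie within the usual scatter of each other, so no order between them can be read. Compound 3 gives a number that lies beyond the scatter from compound 2, on the higher and therefore weaker side.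

Compound 4, `COc1ccc(Cl)cc1S(=O)(=O)Nc1cncc(-c2cccc(C)c2)c1`, has not yet been measured. It derives from compound 2 by one change: 3-methylphenyl in place of carboxy on an aromatic carbon. Going by the values given here, no pair of measured compounds differs in exactly one place, so there is no directly comparable step. Compound 1 also carries an aromatic ring on its core and gives 73 nM, which suggests that an aromatic ring in place of the carboxy group is compatible with a low number. The step of a 1.7-fold lower number from compound 2 to compound 4 (0.22 log units; within the scatter) is therefore expected to be small, toward a lower number, and not clearly beyond the scatter. For compound 4 the estimate is 80 nM, with a range from 30 nM to 250 nM.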

Compound 4, half-maximal inhibitory concentration: 160 nM
The estimate for compound 4 lay 2.0-fold (0.30 log units) below the measured number, within the range that was stated.
By their numbers in this assay, from the lowest: compounds 1, 2, 4 and 3 (each within the scatter of the next, the first and the last beyond it).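

In this assay, putting 3-methylphenyl in place of carboxy on this aromatic carbon, two atoms from the ring nitrogen, gives no readable difference: a 1.2-fold higher number from compound 2 to compound 4 (0.08 log units; within the scatter). The earlier compounds shown here offered no such one-place comparison; this pair shows that, with the rest of the molecule held the same, a carbon-only aromatic ring with no hydrogen-bond donor or acceptor reads the same as the smaller carboxy group, which carries one of each. Nothing measured here accounts for this result.

The compounds shown leave open whether an amine, a longer carbon chain or a plain phenyl ring at this position would also read the same. They also leave open what the methyl on the added ring contributes, and whether the same swap would read alike on a different sulfonamide partner.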